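This account rests on a few compounds, and the source may have more. Where it says the series, first, only, none or still open, it means among the compounds named here.

Compound 1 `COc1ccc(-c2nnc(SC/C(=N/O)c3ccccc3)n2-c2ccccc2)cc1` gives 63% in a functional assay on the whole organism (strain albino) for inhibition, with Rattus norvegicus as the target, read by paw edema, with a stated time of 2 h, at a dose of 0.28 mmol/kg by the oral route; a higher number here means more inhibition at the dose given (going by the name of the read-out), a lower number less inhibition.
Compound 2 `COc1ccc(-c2nnc(SCC(=O)c3ccccc3)n2-c2ccccc2)cc1OC` gives 57% in this assay.
Compound 3 `C=CCn1c(SCC(=O)c2ccccc2)nnc1-c1ccc(OC)c(OC)c1` gives 63% in this assay.

Compound 2 and compound 3 differ in one place, (allyl in place of phenyl on an aromatic nitrogen), and that change made a step of a number 6 percentage points higher from compound 2 to compound 3 (within the scatter). The difference between the core of compound 1 and the core of compound 2 is not broken down here. Compound 1 and compound 3 stand level at the digits shown, together the highest of the three numbers, and compound 2 sits within the scatter of both.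

Compound 4 `C=CCn1c(SC/C(=N/O)c2ccccc2)nnc1-c1ccc(OC)cc1` has not yet been measured. It differs from compound 1 by allyl in place of phenyl on an aromatic nitrogen. This is the same kind of change as that from compound 2 to compound 3, though the surroundings differ: in compound 1 the ring nitrogen is next to the ring atom that bears a 4-methoxyphenyl group and next to the ring atom that bears a large group, whereas in compound 2 it is next to the ring atom that bears a (benzoylmethyl)sulfanyl group and next to the ring atom that bears a 3,4-dimethoxyphenyl group.

Compound 4 is therefore expected to move by about a number 2 percentage points higher from compound 1 to compound 4 (within the scatter) from compound 1, a step of the same small kind, because the earlier step was a number 6 percentage points higher from compound 2 to compound 3 (within the scatter). Compound 4 is estimated at 65% in this assay, expected to fall between 53% and 77%.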

Compound 4, a percentage reported as inhibition, in the whole organism at one dose (the size of the read-out at that dose, not a potency): 66%
For compound 4 the middle estimate is 1 percentage points below the measured one; the range from low to high includes it.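

Allyl in place of phenyl on an aromatic nitrogen gives a step of a number 3 percentage points higher from compound 1 to compound 4 (within the scatter) in this assay. Set beside the earlier step, the change reads alike on both cores: the same change on two cores in this assay, a number 6 percentage points higher (within the scatter) from compound 2 to compound 3 and a number 3 percentage points higher (within the scatter) from compound 1 to compound 4, 3 percentage points apart, within the scatter of two such steps. On these two pairs the change can thus be carried from one core to the other with no difference beyond the scatter, but neither step shows that allyl gives more inhibition than phenyl, and two pairs at one dose and one time say nothing about potency or about other cores.

The compounds shown carry only allyl or phenyl on this ring nitrogen, so it remains open how a longer chain, such as butyl, or a chain ending in an amine would read out there. On these data alone, it is also open whether the change would behave in the same way on a core with a carboxylic acid in place of the 4-methoxyphenyl group.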